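Swapping the amine side chain for an amide on the shared core

A few compounds are considered here, and "the series" means these few. Any claim that something is new, unique, unknown or untested is made for them only; others in the source may bear on it.

Two compounds built on the same thiazole-free description — the shared core — have been checked for how much they harm liver-derived cells. Compound 1 `O=C(Nc1ncc(Cc2ccc(F)cc2)s1)C1CCCCC1` was tested in an ADME assay on HepG2 2.2.15 cells (Homo sapiens) for cytotoxicity; on this read-out lower numbers stand for higher toxicity in this test and higher numbers for lower toxicity in this test. In this test compound 1 gives > 50000 nM, which is a limit of the assay rather than a measured number, so the cells tolerated the highest concentration tried; this is the situation described by the limit of > 50000 nM in this assay, at which 1 of the 2 values shown sits. Compound 2 `CCCCC(CC)CNc1ncc(C(Oc2ccc3cc(Br)ccc3c2)c2ccc(Cl)cc2)s1` carries a large 2-ethylhexyl chain on the ring nitrogen, and in this assay compound 2 is reported as "not toxic" (no number reported), with no single number attached. Compound 2 therefore stands with compound 1 among compounds that showed no measurable toxicity.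

Compound 3 `CC(C)(C)C(=O)Nc1ncc(C(Oc2ccc3cc(Br)ccc3c2)c2ccc(Cl)cc2)s1` has not yet been measured. It differs from compound 2 in one place: (tert-butyl)carbonyl in place of 2-ethylhexyl on a nitrogen on an aromatic ring. Compound 1, which also carries a carbonyl on the ring nitrogen, showed no toxicity, so no step beyond the usual scatter is expected in this assay. The result for compound 3 is expected to be 50000 nM, within a range from 20000 nM to 100000 nM, most likely again reported only as a limit.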

Compound 3, half-maximal cytotoxic concentration: "not toxic" (no number reported)
No number was reported for compound 3, and the estimate cannot be compared.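

For the compounds shown here, compound 2 and compound 3 are both reported as "not toxic" in this assay, with no number for either, so no step between them can be read. The compounds shown leave open what concentration, if any, would harm these cells, and whether (tert-butyl)carbonyl in place of 2-ethylhexyl changes that concentration.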